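A few compounds are considered here, and "the series" means these few. Any claim that something is new, unique, unknown or untested is made for them only; others in the source may bear on it.

Measured compounds in this series:

- Compound 1 `O=c1ccoc2cc(OCc3cn(Cc4ccccc4Br)nn3)ccc12`: in a functional assay on MDA-MB-231 cells (Homo sapiens) for cytotoxicity, read by MTT assay, with a stated time of 48 h (on this read-out higher numbers stand for weaker inhibition and lower numbers for stronger inhibition), compound 1 gives > 100000 nM, which is a limit of the assay.
- Compound 2 `O=c1ccoc2cc(OCc3cn(Cc4cccc(Br)c4)nn3)ccc12`: in this assay compound 2 gives > 100000 nM, again a limit.
- Compound 3 `O=c1ccoc2cc(OCc3cn(Cc4ccc(Cl)cc4)nn3)ccc12`: in this assay compound 3 gives > 100000 nM, also a limit.

Compound 2 therefore stands nowhere on a scale of numbers: it sits at the limit of > 100000 nM in this assay, at which 3 of the 3 values shown sit, and so do both other measured compounds. The three steps between them, a step that the two limits leave unreadable from compound 1 to compound 2, a step that the two limits leave unreadable from compound 1 to compound 3 and a step that the two limits leave unreadable from compound 2 to compound 3, are each unreadable in size, as both ends are limits; all that the data show is that moving the halogen about the benzyl group, or exchanging bromine for chlorine there, never brought the value down into the measurable range.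

Compound 4 `O=c1ccoc2cc(OCc3cn(Cc4ccccc4F)nn3)ccc12` is the next member, not yet measured in this assay. It differs from compound 2 as follows: 2-fluorophenyl in place of 3-bromophenyl on a saturated chain carbon bound to an aromatic nitrogen. This is a change of the same kind as the three measured steps, a halogen and its place on the benzyl group, and those steps give no readable size in either direction. No step beyond the scatter is expected from compound 2 to compound 4, and the most probable outcome is a further limit.

Compound 4 is estimated at 150000 nM, with a range of 40000 nM to 600000 nM, meaning an expected step that the limit leaves unreadable from compound 2 to compound 4.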

Compound 4, half-maximal inhibitory concentration: 29800 nM
Estimate against measurement, compound 4: 5.0-fold (0.70 log units) above; the whole stated range lies above it.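

On the saturated chain carbon bound to an aromatic nitrogen, a change in the halogen and its place can now be read in this assay: 2-fluorophenyl in place of 3-bromophenyl gives an at least 3.3-fold lower number from compound 2 to compound 4 (0.52 log units; beyond the scatter), and 2-fluorophenyl in place of 4-chlorophenyl gives an at least 3.3-fold lower number from compound 3 to compound 4 (0.52 log units; beyond the scatter). The closest comparison keeps the place and changes only the halogen, fluoro in place of bromo on an aromatic carbon, and gives an at least 3.3-fold lower number from compound 1 to compound 4 (0.52 log units; beyond the scatter), so in this pair the identity of the halogen alone separates a readable value from a limit. Compound 4 is the only member shown with a value off that limit, so each of its steps gives only a minimum size: the limit of > 100000 nM in this assay, at which 3 of the 4 values shown sit.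

The steps among compound 1, compound 2 and compound 3 still cannot be read, and the compounds shown do not tell whether fluoro at another place on the phenyl ring would also give a readable value. Also open, going by these compounds, is what an amine or a nitrile on the phenyl ring in place of the halogen, or a longer chain in place of the single saturated carbon, would do to the value.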